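This account rests on a few compounds, and the source may have more. Where it says the series, first, only, none or still open, it means among the compounds named here.

Compound 1 `CC1(C)S[C@@H]2/C(=C\C(=O)c3cc(C(F)(F)F)cc(C(F)(F)F)c3)C(=O)N2[C@H]1C(=O)OC(c1ccccc1)c1ccccc1`: 48500 nM
Compound 2 `CC1(C)S[C@@H]2/C(=C\C(=O)c3ccccc3)C(=O)N2[C@H]1C(=O)OC(c1ccccc1)c1ccccc1`: 12800 nM
Compound 3 `CC1(C)S[C@@H]2C/C(=C\C(=O)c3ccccc3)C(=O)N2[C@H]1C(=O)OC(c1ccccc1)c1ccccc1`: 73300 nM

These three compounds share one core and were all tested in a functional assay on OE19 cells (Homo sapiens) for cytotoxicity, read by MTT assay, with a stated time of 48 h; a lower number here means a stronger inhibitor, a higher number a weaker inhibitor. On the numbers shown, compound 2 stands at the lowest value of the three. Compound 1 sits at a higher number than compound 2 by a gap beyond the usual scatter, and compound 3 sits higher still, also beyond the scatter. Compound 2 is therefore the strongest inhibitor among the measured compounds.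

Compound 4 `CCOC(=O)/C=C1/C(=O)N2[C@@H]1SC(C)(C)[C@@H]2C(=O)OC(c1ccccc1)c1ccccc1` has not yet been measured in this assay. It differs from compound 2 in one place: ethoxy in place of phenyl on a carbonyl carbon. Cut one bond further out, the same change reads benzoyl to ethoxycarbonyl.

For the measured compounds named here, no two measured compounds differ in a single place, so there is no measured step of this kind to lean on. What the numbers do show is that the two departures from compound 2 both gave higher values, beyond the scatter. A step toward a higher number is expected in this assay, though a small one: the expected step is a 2.0-fold higher number from compound 2 to compound 4 (0.29 log units; within the scatter). Compound 4 is estimated at 25000 nM, with a range from 8000 nM to 80000 nM.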

Compound 4, half-maximal inhibitory concentration: 11200 nM
Compound 4: middle estimate off by 2.2-fold (0.35 log units), on the high side; the measured number falls inside the stated range.
By their numbers in this assay, from the lowest: compounds 4 and 2 (each within the scatter of the next); then compounds 1 and 3 (each within the scatter of the next).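

In this assay, putting ethoxy in place of phenyl on a carbonyl carbon gives a 1.1-fold lower number from compound 2 to compound 4 (0.06 log units; within the scatter), so on this pair the benzoyl group and the ethoxycarbonyl group cannot be told apart. For the compounds shown here, the earlier compounds offered no comparison that changed a single place, and this step is the first direct reading of this position: here the aromatic ring of compound 2 can be lost without a change beyond the scatter, even though the entering ethoxy is smaller and brings a hydrogen-bond acceptor. Nothing available explains why the two groups read alike in this cytotoxicity measurement.

Still open, as far as these compounds go, is whether that tolerance extends to other groups on the same carbonyl carbon, such as an amine forming an amide, a free carboxylic acid, or a longer chain like butoxy in place of ethoxy. This single pair also cannot show whether the same swap would read alike on the core of compound 3, where the value for the phenyl version already differs from that of compound 2.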